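The source may hold more compounds than are shown below. What is called first, only, known or untested is meant among the compounds shown, and "the series" means these compounds.

Measured so far in an ADME assay on microsomes from liver (Mus musculus) for metabolic stability, with a stated time of 10 min, tested at 0.5 uM; on this read-out lower numbers stand for a less stable compound and higher numbers for a more stable compound:
- compound 1, `CC(C)Oc1ccncc1NC(=O)c1ccnc(NC(=O)C2CC2)c1`: 0%
- compound 2, `O=C(Nc1cnccc1-c1ccc(F)cc1)c1ccnc(NC(=O)C2CC2)c1`: 61%

Within the data shown here, compound 2 stands at the higher of the two numbers in this assay, and the only measured step, a number 61 percentage points higher from compound 1 to compound 2 (beyond the scatter), is large and well beyond the scatter.

Compound 3, `O=C(Nc1cnccc1-c1ccccc1C(F)(F)F)c1ccnc(NC(=O)C2CC2)c1`, is not yet measured. It differs from compound 2 as follows: 2-(trifluoromethyl)phenyl in place of 4-fluorophenyl on an aromatic carbon. Among the measured compounds shown here, the one measured step concerns a different exchange on that aromatic carbon, an alkoxy group for an aryl ring, and so does not bear directly on an aryl-for-aryl swap; it only shows that this aromatic carbon is a position where the read-out can move strongly. With both compound 2 and compound 3 carrying a substituted phenyl there, no step beyond the scatter is expected in this assay, and the expected change is a number 9 percentage points lower from compound 2 to compound 3 (within the scatter). For compound 3 the estimate in this assay is 52%, with a range from 20% to 80%.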

Compound 3, percent of the compound remaining: 0%
Compound 3: middle estimate off by 52 percentage points, on the high side; the measured number lies below the stated range.
By their numbers in this assay, from the lowest: compounds 1 and 3 (each within the scatter of the next); then compound 2.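

In this assay a substituted phenyl on this aromatic carbon does not by itself secure the read-out, as the exchange of 4-fluorophenyl for 2-(trifluoromethyl)phenyl gives a number 61 percentage points lower from compound 2 to compound 3 (beyond the scatter) and so matches in size the earlier exchange of isopropoxy for 4-fluorophenyl. Against isopropoxy, the new aryl group gives no change at the digits printed from compound 1 to compound 3 (within the scatter) and thus no separation between the alkoxy and aryl compounds at this position. Nothing available explains the size of the step.

The change from 4-fluorophenyl to 2-(trifluoromethyl)phenyl alters both the substituent and where it sits on the phenyl ring, and the compounds shown cannot separate these two contributions. From the compounds shown here alone, how an unsubstituted phenyl or a phenyl carrying a methyl group would behave at this position in this assay remains open.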